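Same aryl swap carried from one core to another

The compounds below may be only part of what the source reports. "The series", "measured", "known", "first", "only" and "open" are said of these compounds alone.

Compound 1 `CNC(=O)c1cc(Oc2ccc(NC(=O)c3nn(-c4cccc(F)c4)c(=O)cc3C)cc2F)ccn1` and compound 2 `CNC(=O)c1cc(Oc2ccc(NC(=O)c3nn(-c4ccc(C)cc4)c(=O)cc3C)cc2F)ccn1` share one core; compound 3 `Cc1cc(=O)n(-c2cccc(F)c2)nc1C(=O)Nc1ccc(Oc2ncnc3sccc23)cc1` and compound 4 `Cc1ccc(-n2nc(C(=O)Nc3ccc(Oc4ncnc5sccc45)cc3)c(C)cc2=O)cc1` share another, and the difference between the two cores is not broken down here. In a functional assay on MCF7 cells (Homo sapiens) for cytotoxicity, read by MTT assay, with a stated time of 72 h (on this read-out higher numbers stand for weaker inhibition and lower numbers for stronger inhibition), compound 1 gives 6410 nM and compound 2 gives 8380 nM; the change of 4-methylphenyl in place of 3-fluorophenyl on an aromatic nitrogen made a step of a 1.3-fold higher number from compound 1 to compound 2 (0.12 log units; within the scatter). In this assay compound 3 gives 27200 nM, the highest number of the three measured, with its steps to compound 2 and compound 1 both beyond the scatter. Compound 4 carries the same change on the second core, (4-methylphenyl in place of 3-fluorophenyl on an aromatic nitrogen), at the same place. For compound 4 a step of a 1.2-fold higher number from compound 3 to compound 4 (0.07 log units; within the scatter) is expected, resting on a 1.3-fold higher number from compound 1 to compound 2 (0.12 log units; within the scatter), which lay within the scatter. Compound 4 is estimated at 32000 nM in this assay, with a range from 12000 nM to 85000 nM.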

Compound 4, half-maximal inhibitory concentration: > 40000 nM
Compound 4 gave a limit, no number; the forecaster's own chance of this, stated with the estimate: 20%; middle value at least 1.2-fold (0.09 log units) away from the limit.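

Compound 4 gave only a limit in this assay, > 40000 nM, and not a number. The step on the core of compound 3 therefore stands as a floor, an at least 1.4-fold higher number from compound 3 to compound 4 (0.16 log units; that floor lies within the scatter), and shows that 4-methylphenyl in place of 3-fluorophenyl gave no lower number on this core, but not how large the step is. Whether the change carries the same size from one core to the other stays undecided: the same change on two cores in this assay, a 1.3-fold higher number (0.12 log units; within the scatter) from compound 1 to compound 2 and an at least 1.4-fold higher number (0.16 log units; that floor lies within the scatter) from compound 3 to compound 4; the limit leaves it open whether they differ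

From the compounds shown here alone, the true size of the step on the core of compound 3 remains open, since only a floor is in hand. Also open, going by these compounds, is how an aryl group bearing an amine or a carboxylic acid would read on either core.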